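Fluoro to iodo on compound 2

A few compounds are considered here, and "the series" means these few. Any claim that something is new, unique, unknown or untested is made for them only; others in the source may bear on it.

Within the data shown here, in a functional assay on MCF7 cells (Homo sapiens) for cytotoxicity, read by MTT assay, with a stated time of 48 h (on this read-out lower numbers stand for stronger inhibition and higher numbers for weaker inhibition), compound 2 (`CC(=NNC(=S)Nc1cccc(F)c1)c1ccccn1`) gives 9 nM and stands lowest of the two numbers so far, while compound 1 (`CC(=NNC(=S)Nc1cccc([N+](=O)[O-])c1)c1ccccn1`) gives 38 nM as the higher one. Compound 3 (`CC(=NNC(=S)Nc1cccc(I)c1)c1ccccn1`) has iodo in place of fluoro on an aromatic carbon. Among the measured compounds shown here, the only measured step, fluoro in place of nitro on that same carbon, was modest (a 4.2-fold lower number from compound 1 to compound 2 (0.63 log units; beyond the scatter)). A step of similar or smaller size is therefore expected in this assay as well, probably toward a higher number. The estimated step is modest (a 1.6-fold higher number from compound 2 to compound 3 (0.19 log units; within the scatter)). Compound 3 is expected at 14 nM with a range of 4 nM to 50 nM as the estimate.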

Compound 3, half-maximal inhibitory concentration: 45 nM
For compound 3 the middle estimate is 3.2-fold (0.51 log units) below the measured one; the measured number falls inside the stated range.
By their numbers in this assay, from the lowest: compound 2; then compounds 1 and 3 (each within the scatter of the next).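

On this aromatic carbon, this assay gives a 5.0-fold higher number from compound 2 to compound 3 (0.70 log units; beyond the scatter) when iodo replaces fluoro, so fluoro now stands apart from two different groups rather than one. Iodo and nitro cannot be told apart here, with a 1.2-fold higher number from compound 1 to compound 3 (0.07 log units; within the scatter) between them, which leaves compound 2 alone at the low end of these three. No measurement shown here accounts for this difference.

On these data alone, whether chloro, bromo or an amine on this carbon would fall with fluoro or with iodo and nitro stays open. So does whether fluoro would hold its standing on another carbon of the ring.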